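The compounds below may be only part of what the source reports. "The series", "measured", "known", "first", "only" and "open" are said of these compounds alone.

For the measured compounds named here, in an assay on membranes from brain for displacement of a labelled ligand from Neuronal acetylcholine receptor; alpha4/beta2 (Rattus norvegicus) (a lower number here means a stronger inhibitor, a higher number a weaker inhibitor), compound 3 `CN1CCC[C@H]1COc1cncc(C(F)(F)F)c1` gives 1.83 nM, the lowest of the three numbers so far. Compound 1 `Cc1ncccc1OC[C@@H]1CCCN1C` gives 22.9 nM, and compound 2 `CN1CCC[C@H]1COc1cccnc1I` gives 606 nM. Compound 4 `COC(=O)c1cncc(OC[C@@H]2CCCN2C)c1` has not yet been measured; it differs from compound 3 by methoxycarbonyl in place of trifluoromethyl on an aromatic carbon. Going by the values given here, the only measured step between two compounds that differ in one place is a 26-fold higher number from compound 1 to compound 2 (1.42 log units; beyond the scatter), which shows that exchanging one group on an aromatic carbon of the shared core can move the number a long way. Among the compounds with values here, no measured pair exchanges trifluoromethyl for methoxycarbonyl, so the expectation rests on that single step. A rise is expected, though a more modest one: the estimated step is an 11-fold higher number from compound 3 to compound 4 (1.04 log units; beyond the scatter). For compound 4 the estimated value is 20 nM, with a range from 4 nM to 100 nM.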

Compound 4, inhibition constant: 1.45 nM
Compound 4: the middle estimate sits 14-fold (1.14 log units) above what was measured; the measured number lies below the stated range.
By their numbers in this assay, from the lowest: compounds 4 and 3 (each within the scatter of the next); then compound 1; then compound 2.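

In this assay, methoxycarbonyl in place of trifluoromethyl, two atoms from the ring nitrogen, gives a 1.3-fold lower number from compound 3 to compound 4 (0.10 log units; within the scatter) and so stays within the scatter. This position therefore tolerates the exchange, even though methoxycarbonyl brings hydrogen-bond acceptors and trifluoromethyl has none, so a group exchange on the shared core need not move the number far. Nothing measured here explains why these two groups give such similar numbers.

Going by these compounds, whether an amine or a carboxylic acid at this position would also keep the number this low remains open. So does the effect of a longer chain on the ester.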